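The source may report more compounds than this note shows. Statements on the series, on what has been measured and on what is new or still open speak of the compounds shown alone.

The series holds four compounds. Compound 1 `CN1CCc2nc(N)ncc2C1` carries an amino group, and compound 2 `CN1CCc2ncncc2C1` is its counterpart with hydrogen in that place. Compound 3 `Nc1ncc2c(n1)CCCCCCCCCC2` carries the same amino group on a different core, and compound 4 `c1ncc2c(n1)CCCCCCCCCC2` is its hydrogen counterpart, still unmeasured. In a functional assay on the whole organism for inhibition, with Rattus norvegicus as the target, with stated times of 1 h and 3.5 h, at a dose of 100 mg/kg by the oral route (on this read-out lower numbers stand for less inhibition and higher numbers for more inhibition at the one dose given (going by the name of the read-out)), compound 1 gives < 5%, which is a limit of the assay rather than a number. In this assay compound 2 gives 50%. The step of a number at least 45 percentage points higher from compound 1 to compound 2 (beyond the scatter) accompanies the change (hydrogen in place of amino on an aromatic carbon). In this assay compound 3 gives < 5%, again a limit. The difference between the two cores is not broken down here. The change hydrogen in place of amino on an aromatic carbon is the same kind of change as that from compound 1 to compound 2. Among the measured compounds shown here, because compound 1 and compound 3 both sit at the limit of < 5% in this assay, at which 2 of the 3 values shown sit, the measured step of a number at least 45 percentage points higher from compound 1 to compound 2 (beyond the scatter) is the only guide. The step is expected to be a number at least 30 percentage points higher from compound 3 to compound 4 (beyond the scatter). Compound 4 is expected to give 35%, between 5% and 65%.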

Compound 4, a percentage reported as inhibition, in the whole organism at one dose (the size of the read-out at that dose, not a potency): < 5%
Compound 4 ended at the assay's limit; the forecaster's own chance of this, stated with the estimate: 25%; middle value at least 30 percentage points from the limit.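

Compound 3 and compound 4 both sit at a limit of the assay rather than at a number, so no step can be read between them: the limit of < 5% in this assay, at which 3 of the 4 values shown sit. The compounds shown leave open whether hydrogen in place of amino changes anything on the core of compound 3 in this assay.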